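The source may hold more compounds than are shown below. What is called first, only, known or untested is meant among the compounds shown, and "the series" means these compounds.

Working notes on the series. Compound 1 `COc1cc(/C(=N/N)c2ccc3c(ccn3C)c2)cc(OC)c1OC` gives in a functional assay on HL-60 cells (Homo sapiens) for cytotoxicity, read by XTT assay, with a stated time of 72 h (on this read-out lower numbers stand for stronger inhibition and higher numbers for weaker inhibition), only > 10000 nM, which is a limit of the assay and not a number. Compound 2 `CCn1ccc2cc(/C(=N\N)c3cc(OC)c(OC)c(OC)c3)ccc21` gives in this assay > 1000 nM, again a limit rather than a measured number. Within the data shown here, the single step between measured compounds, a step that the two limits leave unreadable from compound 1 to compound 2, therefore cannot be read, its two ends resting at the limit of > 10000 nM in this assay, at which 1 of the 2 values shown sits, and (the limit of > 1000 nM in this assay, at which 1 of the 2 values shown sits). Compound 3 `COc1cc(/C(=N/C(=O)OC(C)(C)C)c2ccc3c(ccn3C)c2)cc(OC)c1OC` differs from compound 1 by tert-butoxycarbonyl in place of amino on a double-bonded nitrogen. No measured step bears on this change: the one step shown concerns the group on the aromatic nitrogen and is itself unreadable. Compound 1 stands at a limit, so the change can only be judged against that limit. Compound 3 is expected to stay weak, with an estimated step that the limit leaves unreadable from compound 1 to compound 3 in this assay of no readable size. Compound 3 is estimated at 20000 nM, between 5000 nM and 80000 nM, and will most likely again be reported only as a limit.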

Compound 3, half-maximal inhibitory concentration: > 1000 nM
Compound 3 gave a limit, no number; the forecaster's own chance of this, stated with the estimate: 70%; the middle value lies beyond the limit too.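

Among these compounds, compound 1 and compound 3 both rest at limits of the assay rather than at numbers, so no step between them can be read in this assay. The compounds shown leave open whether tert-butoxycarbonyl in place of amino on a double-bonded nitrogen changes the read-out at all.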